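This account rests on a few compounds, and the source may have more. Where it says the series, first, only, none or still open, it means among the compounds named here.

Series notes on the shared core. Compound 1 `CC(C)S(=O)(=O)c1ccccc1NCC1=NCCN1` carries an isopropylsulfonyl group; in an assay on CHO cells for binding affinity to Alpha-2B adrenergic receptor (Homo sapiens), read by radioligand binding (on this read-out higher numbers stand for weaker inhibition and lower numbers for stronger inhibition), compound 1 gives only a limit, < 6310 nM, and no number. That limit is the limit of < 6310 nM in this assay, at which 1 of the 3 values shown sits, a boundary of the assay rather than a measurement. Compound 2 `CSc1cc(F)ccc1NCC1=NCCN1` gives 851 nM in this assay. Compound 3 `CSc1c(F)cccc1NCC1=NCCN1` gives 3980 nM in this assay. Within the data shown here, no two of the measured compounds differ in a single place, so no measured step exists against which a new change could be calibrated.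

Compound 4 `CCS(=O)(=O)c1ccccc1NCC1=NCCN1` differs from compound 1 by hydrogen in place of methyl on a saturated chain carbon bound to a saturated chain carbon and a sulfonyl sulfur. No shown step covers this change, and compound 1 itself supplies only a limit. The expected step is accordingly small, a step that the limit leaves unreadable from compound 1 to compound 4, with no direction established beyond the scatter. Compound 4 is expected to give 3000 nM in this assay, with a range from 800 nM to 12000 nM.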

Compound 4, inhibition constant: < 6310 nM
Compound 4 gave a limit, no number; the forecaster's own chance of this, stated with the estimate: 40%; the middle value is on the limit's open side.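

Compound 1 and compound 4 each give only a limit, not a number, in this assay, so no step can be read between them: the limit of < 6310 nM in this assay, at which 2 of the 4 values shown sit.

The compounds shown leave open how large the change from isopropylsulfonyl to ethylsulfonyl is, and in which direction it runs.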